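Anilide variation on the shared core: compound 4 expected

The source may report more compounds than this note shows. Statements on the series, on what has been measured and on what is new or still open speak of the compounds shown alone.

Working notes on a small series sharing one core, with the anilide group as the only variable. Compound 1 is `CN(C)C(=O)c1cc2cnc(Nc3ccc(NC(=O)C4(C(=O)Nc5ccc(Cl)c(C(F)(F)F)c5)CC4)cc3)nc2n1C1CCCC1`; in a functional assay on T47D cells (Homo sapiens) for inhibition, read by CCK-8 assay, with a stated time of 72 h, tested at 1 uM (on this read-out higher numbers stand for more inhibition of growth at the one concentration tested and lower numbers for less inhibition of growth), compound 1 gives 6.9%, the lowest of the three numbers measured. Compound 2 is `CN(C)C(=O)c1cc2cnc(Nc3ccc(NC(=O)C4(C(=O)Nc5cccc(Br)c5)CC4)cc3)nc2n1C1CCCC1` and in this assay compound 2 gives 29.1%. Compound 3 is `COc1cccc(NC(=O)C2(C(=O)Nc3ccc(Nc4ncc5cc(C(=O)N(C)C)n(C6CCCC6)c5n4)cc3)CC2)c1` and in this assay compound 3 gives 56.3%. The steps read a number 22.2 percentage points higher from compound 1 to compound 2 (beyond the scatter) and a number 49.4 percentage points higher from compound 1 to compound 3 (beyond the scatter), and between the two anilides a number 27.2 percentage points higher from compound 2 to compound 3 (beyond the scatter).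

Compound 4 is `CN(C)C(=O)c1cc2cnc(Nc3ccc(NC(=O)C4(C(=O)Nc5ccc(C(F)(F)F)cc5)CC4)cc3)nc2n1C1CCCC1`. Against compound 1 the difference is 4-(trifluoromethyl)phenyl in place of 4-chloro-3-(trifluoromethyl)phenyl on an amide-type nitrogen. Going by the values given here, both measured steps away from compound 1 go upward in this assay, the one toward compound 2 being the nearer analogue of this change, since it too removes substitution from the anilide ring; the one toward compound 3 is larger and less comparable. On that basis a modest upward step is expected, a number 15.1 percentage points higher from compound 1 to compound 4 (beyond the scatter). Compound 4 is therefore estimated at 22% in this assay, within 5% to 45%.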

Compound 4, percent growth inhibition at one concentration: 29.6%
Compound 4: the middle estimate sits 7.6 percentage points below what was measured; the measured number falls inside the stated range.
By their numbers in this assay, from the lowest: compound 1; then compounds 2 and 4 (each within the scatter of the next); then compound 3.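

In this assay, 4-(trifluoromethyl)phenyl in place of 4-chloro-3-(trifluoromethyl)phenyl on the amide-type nitrogen gives a number 22.7 percentage points higher from compound 1 to compound 4 (beyond the scatter), so a change that takes out the chlorine and leaves the trifluoromethyl group on the ring is enough to give a step beyond the scatter. Two different anilides now read alike, with a number 0.5 percentage points higher from compound 2 to compound 4 (within the scatter), whereas 3-methoxyphenyl stays clear of the new anilide, with a number 26.7 percentage points lower from compound 3 to compound 4 (beyond the scatter), and compound 3 remains above the other three compounds. No evidence at hand explains these steps.

The compounds shown do not separate the loss of the chlorine from the different ring placement of the trifluoromethyl group, which 3-(trifluoromethyl)phenyl would address. Also open, from the compounds shown here alone, is whether the level of compound 3 is specific to methoxy or extends to 3-ethoxyphenyl, 4-methoxyphenyl or 3-aminophenyl.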